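This account rests on a few compounds, and the source may have more. Where it says the series, first, only, none or still open, it means among the compounds named here.

Compound 3 `CN1CCC(CCn2c(N)nc3ccc(C(=O)c4ccccc4)cc32)CC1` is one of three compounds that share a core and have been tested in an ADME assay on CRL8155 cells (Homo sapiens) for cytotoxicity, read by resazurin assay, with a stated time of 72 h; a higher number here means that more compound is needed for the effect, a lower number that less compound is needed. In this assay compound 3 gives > 30000 nM, which is a limit of the assay rather than a number. Compound 1 `O=C(c1ccccc1)c1ccc2nc(NCCO)[nH]c2c1` gives > 30000 nM in this assay, again a limit. Compound 2 `CN1CCC(Cn2c(N)nc3ccc(C(=O)c4ccccc4)cc32)CC1` gives > 30000 nM in this assay, also a limit. The step that the two limits leave unreadable from compound 2 to compound 3 therefore cannot be read, and the same holds for any comparison among these three, because of the limit of > 30000 nM in this assay, at which 3 of the 3 values shown sit.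

Compound 4 `Nc1nc2ccc(C(=O)c3ccccc3)cc2n1C[C@H]1CCCN1` differs from compound 3 by pyrrolidin-2-yl in place of (1-methylpiperidin-4-yl)methyl on a saturated chain carbon bound to an aromatic nitrogen. Within the data shown here, no measured step bears on this change, since every value so far sits at the limit. Among the measured compounds shown here, the only guide is that all three known values sit at that limit, so compound 4 is expected to behave the same way in this assay, with the step that the limit leaves unreadable from compound 3 to compound 4 expected to be unreadable in either direction. On that basis compound 4 is estimated to give about 40000 nM in this assay, within 15000 nM to 100000 nM.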

Compound 4, half-maximal effective concentration: > 30000 nM
Compound 4 gave a limit, no number; the forecaster's own chance of this, stated with the estimate: 85%; the middle value does not contradict the limit.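

In this assay compound 4 gives > 30000 nM as a limit and not a number, so the steps to compound 4 from compound 2 and compound 3 cannot be read: the limit of > 30000 nM in this assay, at which 4 of the 4 values shown sit. The compounds shown leave open what concentration of any of them harms these cells, and whether changing the group on the saturated chain carbon alters it.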